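Three Aryl-Substituted Pyridines and a Fourth Awaiting Measurement

A few compounds are considered here, and "the series" means these few. Any claim that something is new, unique, unknown or untested is made for them only; others in the source may bear on it.

Compound 1 `c1coc(-c2ccnc(-c3cccs3)c2)c1`, compound 2 `c1ccc(-c2cc(-c3cccs3)cc(-c3ccco3)n2)cc1` and compound 3 `c1ccc(-c2cc(-c3cccs3)nc(-c3cccs3)c2)nc1` were all tested in a functional assay on HCT-15 cells (Homo sapiens) for antiproliferative activity; on this read-out lower numbers stand for an effect already at smaller amounts and higher numbers for an effect only at larger amounts of compound. In this assay compound 1 gives 118000 nM, compound 2 gives 118000 nM and compound 3 gives 118000 nM. Compound 3 therefore stands level with compounds 1 and 2 at the digits shown; its nearest neighbour is compound 1, with no change at those digits, and its furthest is compound 2, again with no change at those digits, both within the usual scatter of this assay.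

Compound 4 `c1csc(-c2cc(-c3cccs3)nc(-c3cccs3)c2)c1` has not yet been measured. It differs from compound 3 in one place: thiophen-2-yl in place of pyridin-2-yl on an aromatic carbon. Within the data shown here, no pair of measured compounds shows the effect of this particular exchange, so the expectation for compound 4 rests on the fact that the three measured compounds, which carry different aromatic groups on the shared core, all sit at the same reading.

For compound 4 the step of no change at the digits printed from compound 3 to compound 4 (within the scatter) is expected to be none beyond the scatter. Compound 4 is accordingly estimated at 118000 nM in this assay, with a range from 50000 nM to 250000 nM.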

Compound 4, half-maximal effective concentration: 118000 nM
Compound 4: middle estimate and measured number agree at the digits printed; low and high end bracket the measured number.
By their numbers in this assay, from the lowest: compounds 1, 2, 3 and 4 (each within the scatter of the next).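

In this assay, among these compounds, the exchange of pyridin-2-yl for thiophen-2-yl gives no change at the digits printed from compound 3 to compound 4 (within the scatter) and so offers the first direct reading of a single change at this position, the aromatic carbon opposite the ring nitrogen. At this place a six-membered aromatic ring holding nitrogen and a five-membered aromatic ring holding sulfur read alike, even though the entering group has one heavy atom fewer and the hetero atom differs. No measurement available here explains this sameness.

Going by these compounds, both groups compared at this position are aromatic rings with 1 hetero atom, so whether an amine, a carboxylic acid or a longer alkyl chain placed there would shift the reading stays open. Also open, on these data alone, is whether exchanging either of the two thiophen-2-yl groups would leave the reading in place, and whether the exchange of pyridin-2-yl for thiophen-2-yl would read the same on a core that gives a clearly lower number.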